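Aryl Swaps on a Shared Core Leave Efficacy Flat

This account rests on a few compounds, and the source may have more. Where it says the series, first, only, none or still open, it means among the compounds named here.

Measured compounds:
compound 1, `O=C(O)Cc1sc(C(c2ccc(F)cc2)c2ccc(F)cc2)nc1-c1cc(F)nc(F)c1`, 80%
compound 2, `O=C(O)Cc1sc(C(c2ccc(F)cc2)c2ccc(F)cc2)nc1-c1cc(F)cc(F)c1`, 80%
compound 3, `O=C(O)Cc1sc(C(c2ccc(F)cc2)c2ccc(F)cc2)nc1-c1ccco1`, 80%

In an in vitro functional assay on HEK285-7 cells for antagonist activity at prostaglandin D2 receptor 2 (Homo sapiens), read by BRET and beta-arrestin recruitment (on this read-out higher numbers stand for larger maximal responses and lower numbers for smaller maximal responses), compound 3 stands level with compounds 1 and 2; the nearest of them is compound 1 and the furthest compound 2, and in neither case does the gap leave the scatter.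

Compound 4, `Cc1cc(-c2nc(C(c3ccc(F)cc3)c3ccc(F)cc3)sc2CC(=O)O)cnc1N`, is not yet measured. It differs from compound 3 in one place: 6-amino-5-methylpyridin-3-yl in place of furan-2-yl on an aromatic carbon.

Going by the values given here, three measured steps bear on this kind of exchange of the group on that aromatic carbon: no change at the digits printed from compound 1 to compound 2 (within the scatter), no change at the digits printed from compound 1 to compound 3 (within the scatter) and no change at the digits printed from compound 2 to compound 3 (within the scatter). Each of them swapped one aromatic group for another at the same place, and none of them moved the maximal response beyond the scatter. None of those swaps brought in a group like the one entering here, so the expectation rests on the flatness of the series alone. On that basis no step beyond the scatter is expected in this assay, in either direction, and the step of no change at the digits printed from compound 3 to compound 4 (within the scatter) is expected to be small.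

Compound 4 is therefore estimated to give 80% in this assay, with a range from 65% to 95%.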

Compound 4, largest response reached (reported as efficacy), in percent of the reference or control that the assay uses: 80%
Beside the measured number, compound 4's estimate shows no gap at the digits printed, and the stated range covers the measured number.
By their numbers in this assay, from the lowest: compounds 1, 2, 3 and 4 (each within the scatter of the next).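

In this assay, placing 6-amino-5-methylpyridin-3-yl on the aromatic carbon next to the ring nitrogen gives no change at the digits printed from compound 3 to compound 4 (within the scatter), and the comparisons with the two fluorinated aryl compounds give no change at the digits printed from compound 2 to compound 4 (within the scatter) and no change at the digits printed from compound 1 to compound 4 (within the scatter). The flat response at this position therefore extends beyond the aryl groups seen earlier to a six-membered aromatic ring bearing an amino group and a methyl group, with 8 heavy atoms against 5 in furan-2-yl and with a hydrogen-bond donor that furan-2-yl lacks. No supporting evidence is available to explain why the maximal response stays level across these exchanges.

The compounds shown leave open whether the response would stay level with a non-aromatic group at this position, such as a morpholine or a cyclohexyl ring, or with a carboxylic acid on the incoming aromatic ring. They also leave open whether this tolerance would hold if the carboxymethyl group on the neighbouring ring atom were exchanged for a longer chain or an amide.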